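Catechol-bearing amides: one ring swap, twice over

The compounds below may be only part of what the source reports. "The series", "measured", "known", "first", "only" and "open" are said of these compounds alone.

Of the compounds shown here, three have been measured in a functional assay, with a stated time of 30 min, in the absence of a further agent; on this read-out lower numbers stand for stronger inhibition and higher numbers for weaker inhibition. Compound 1 `Cc1ccc(C(=O)Nc2nnc(-c3ccc(O)c(O)c3)s2)cc1` gives 34000 nM in this assay. Compound 2 `O=C(Nc1nnc(-c2ccc(O)c(O)c2)s1)C1CCCCC1` carries cyclohexyl in place of 4-methylphenyl on a carbonyl carbon and gives 37300 nM in this assay; the step from the first to the second is a 1.1-fold higher number from compound 1 to compound 2 (0.04 log units; within the scatter). Compound 3 `Cc1ccc(C(=O)Nc2nnc(-c3cccc(O)c3O)s2)cc1` shares its atoms with compound 1 but joins them differently, and the difference between the two cores is not broken down here. In this assay compound 3 gives 27100 nM. Its number is nearest to that of compound 1, with compound 2 furthest away, and both gaps are within the scatter, so no order among the three can be drawn from these numbers.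

Compound 4 `O=C(Nc1nnc(-c2cccc(O)c2O)s1)C1CCCCC1` has not yet been measured in this assay. It differs from compound 3 by cyclohexyl in place of 4-methylphenyl on a carbonyl carbon. This is the same change that was made from compound 1 to compound 2, at the same place, on the same kind of carbonyl carbon, and that change made a step within the scatter. Because a 1.1-fold higher number from compound 1 to compound 2 (0.04 log units; within the scatter) lies within the scatter, the step from compound 3 to compound 4 in this assay is expected to be a 1.1-fold higher number from compound 3 to compound 4 (0.04 log units; within the scatter), with no clear movement in either direction. On that basis compound 4 is estimated to give 30000 nM in this assay, expected to fall between 15000 nM and 60000 nM.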

Compound 4, half-maximal inhibitory concentration: 19900 nM
Compound 4: the middle estimate sits 1.5-fold (0.18 log units) above what was measured; low and high end bracket the measured number.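

In this assay the swap of 4-methylphenyl for cyclohexyl on a carbonyl carbon gives a 1.4-fold lower number from compound 3 to compound 4 (0.13 log units; within the scatter) on the core shared by compound 3 and compound 4. Neither this step nor the earlier one is a clear movement, so the series offers no measurable effect of the change that could be said to carry over, and two pairs cannot establish how it would behave on any other core. What the pairs do show is that an aromatic and a non-aromatic six-membered carbon ring are not told apart on either core in this assay, and that the two cores give steps that cannot be separated: the same change on two cores in this assay, a 1.1-fold higher number (0.04 log units; within the scatter) from compound 1 to compound 2 and a 1.4-fold lower number (0.13 log units; within the scatter) from compound 3 to compound 4, 1.5-fold (0.17 log units) apart, within the scatter of two such steps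

The compounds shown leave open whether any group on this carbonyl carbon would move the number beyond the scatter, for instance a chain ending in an amine or a carboxylic acid, or a short open alkyl chain in place of the ring. They also leave open whether the swap would behave the same way on a core in which methoxy groups take the place of the two hydroxyl groups.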